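Demethylation of a phenolic ether in a thioester series

The source may report more compounds than this note shows. Statements on the series, on what has been measured and on what is new or still open speak of the compounds shown alone.

Of the compounds shown here, three of the shared core have been tested in a functional assay on HCT-116 cells (Homo sapiens) for cytotoxicity, read by sulforhodamine B assay, with a stated time of 72 h; a higher number here means a weaker inhibitor, a lower number a stronger inhibitor. Compound 1 `CSC(=O)c1c(C(C)C)cc(O)c(C)c1O[C@@H]1O[C@H](CO)[C@@H](O)[C@H](O)[C@H]1O` carries a glycoside on the core; in this assay compound 1 gives > 40000 nM, which is a limit of the assay and not a number. Compound 2 `CSC(=O)c1c(O[C@@H]2O[C@H](COC(C)=O)[C@@H](O)[C@H](O)[C@H]2O)c(C)c(O)c(C)c1C(C)C` bears an acetylated glycoside; in this assay compound 2 gives > 40000 nM, again a limit. Compound 3 `COc1c(C)c(O)c(C)c(C(C)C)c1C(=O)SC` has a methoxy group in place of the sugar; in this assay compound 3 gives > 40000 nM, also a limit. Among the compounds with values here, compound 3 therefore stands nowhere distinguishable from the other two: all three values sit at the limit of > 40000 nM in this assay, at which 3 of the 3 values shown sit, and no step between measured compounds can be computed.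

Compound 4 `CSC(=O)c1c(O)c(C)c(O)c(C)c1C(C)C` is the next compound to be measured. It differs from compound 3 by hydrogen in place of methyl on an oxygen on an aromatic ring. Nothing in the measured set shows that this change, or any change, moves a value off the limit, so no step beyond the scatter is expected in this assay. The step expected is a number no higher from compound 3 to compound 4 (the limit leaves the size open), that is, none that the assay would resolve. Compound 4 is expected to give 40000 nM in this assay, with a range from 10000 nM to 160000 nM, most probably reported again as a limit.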

Compound 4, half-maximal inhibitory concentration: 3900 nM
The estimate for compound 4 lay 10-fold (1.01 log units) above the measured number, outside the stated range (below it).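

Compound 3 gives > 40000 nM in this assay, which is a limit of the assay and not a number. The change from methoxy to hydroxy, hydrogen in place of methyl on an oxygen on an aromatic ring, gives an at least 10-fold lower number from compound 3 to compound 4 (1.01 log units; beyond the scatter), which makes this oxygen the first place in the series where a single change is seen to bring a value off the limit, and it shows that a free hydroxy here is compatible with measurable cytotoxicity on the shared core. Compound 4 therefore serves as the only numerical reference point for further comparison, and the rest of the set offers no number to set against it: the limit of > 40000 nM in this assay, at which 3 of the 4 values shown sit.

The true size of the step stays open, since one end of it is a limit, and the data give no reason for the change. From the compounds shown here alone, whether an amine in place of this hydroxy, or a longer chain such as ethyl on this oxygen, would hold the value off the limit is also open, as is whether the other hydroxy on the core matters in the same way.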